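This account rests on a few compounds, and the source may have more. Where it says the series, first, only, none or still open, it means among the compounds named here.

Measured so far in a functional assay on L6 cells (Rattus norvegicus) for cytotoxicity; a lower number here means a stronger inhibitor, a higher number a weaker inhibitor
compound 1 `Nc1nc(N)nc(N/N=C/c2ccc([N+](=O)[O-])o2)n1` gives 183000 nM
compound 2 `CN(C)c1nc(N/N=C/c2ccc([N+](=O)[O-])o2)nc(N(C)C)n1` gives 18700 nM

Of the two, compound 2 has the lower number, with 18700 nM against compound 1 at 183000 nM in the same read-out. This gap lies beyond the scatter, so compound 2 is the stronger inhibitor of the pair.

The next compound is compound 3 `CN(C)c1nc(N)nc(N/N=C/c2ccc([N+](=O)[O-])o2)n1`, which has not yet been measured. Relative to compound 2, it has amino in place of dimethylamino on an aromatic carbon, between two ring nitrogen atoms (amino in place of dimethylamino on an aromatic carbon). Compound 3 therefore carries the amino group of compound 1 together with the dimethylamino group of compound 2.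

Among the compounds with values here, no step in a single place has been measured, so the expectation rests on two values only. A move to a higher number is expected, part of the way towards compound 1 at 183000 nM without reaching it. The expected size is a 2.9-fold higher number from compound 2 to compound 3 (0.47 log units; beyond the scatter) in this assay and would lie modestly beyond the scatter. The estimated value for compound 3 is 55000 nM (expected range 22000 nM to 140000 nM).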

Compound 3, half-maximal inhibitory concentration: 110000 nM
Compound 3: the middle estimate sits 2.0-fold (0.30 log units) below what was measured; the measured number falls inside the stated range.
By their numbers in this assay, from the lowest: compound 2; then compounds 3 and 1 (each within the scatter of the next).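

In this assay, amino in place of dimethylamino on this aromatic carbon, with a dimethylamino group still meta to it, gives a 5.9-fold higher number from compound 2 to compound 3 (0.77 log units; beyond the scatter), so this exchange has a readable effect when that partner group is present. The opposite exchange, dimethylamino in place of amino with an amino group remaining on the core, gives a 1.7-fold lower number from compound 1 to compound 3 (0.22 log units; within the scatter), which is within the scatter and shows no readable effect. The same pair of groups therefore reads differently in these two steps: only the step that leaves or gains the second dimethylamino group stands beyond the scatter, and no measurement shown here accounts for that difference.

The compounds shown leave open whether this step is specific to dimethylamino or would also appear with methylamino, diethylamino or morpholine on the same aromatic carbon. They also leave open whether a hydroxyl group or a methoxy group there would fall with amino or with dimethylamino in this assay, and whether the two steps would keep their difference with another group in place of the nitro group.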